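The compounds below may be only part of what the source reports. "The series", "measured", "known", "first", "only" and "open" are said of these compounds alone.

In a functional assay on MDA-MB-231 cells (Homo sapiens) for inhibition, read by MTT assay, with a stated time of 5 days (a higher number here means a weaker inhibitor, a lower number a stronger inhibitor), three compounds sharing one core have been measured: compound 1 (`Cc1cc(Nc2nc(NCc3ccc(Cl)cc3)nc3[nH]ncc23)n[nH]1`) gives 7500 nM, compound 2 (`Cc1cc(Nc2nc(NCc3ccc(Br)cc3)nc3[nH]ncc23)n[nH]1`) gives 1860 nM, and compound 3 (`Cc1cc(Nc2nc(NCc3ccc(F)cc3F)nc3[nH]ncc23)n[nH]1`) gives 2670 nM. That puts the last of these level with one neighbour and clearly apart from the other: a 1.4-fold higher number from compound 2 to compound 3 (0.16 log units; within the scatter), and a 2.8-fold lower number from compound 1 to compound 3 (0.45 log units; beyond the scatter). Compound 4 (`Cc1cc(Nc2nc(NCc3ccc(F)cc3F)nc3c2cnn3C2CCOCC2)n[nH]1`) carries oxan-4-yl in place of hydrogen on an aromatic nitrogen. The measured steps, including a 4.0-fold lower number from compound 1 to compound 2 (0.61 log units; beyond the scatter), all alter the halogenated phenyl group, and none changes this nitrogen. They give no direction, so no step beyond the scatter is expected, though the uncertainty is wide. The expected change is a 1.1-fold lower number from compound 3 to compound 4 (0.03 log units; within the scatter). For compound 4 the estimated value is 2500 nM, with an expected range of 500 nM to 12000 nM.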

Compound 4, half-maximal inhibitory concentration: 2880 nM
Estimate against measurement, compound 4: 1.2-fold (0.06 log units) below; low and high end bracket the measured number.
By their numbers in this assay, from the lowest: compounds 2, 3 and 4 (each within the scatter of the next); then compound 1.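

In this assay, oxan-4-yl in place of hydrogen on an aromatic nitrogen gives a 1.1-fold higher number from compound 3 to compound 4 (0.03 log units; within the scatter). The earlier compounds shown here differed only in the halogenated phenyl group, whereas this result shows that a hydrogen on this nitrogen can give way to a six-membered non-aromatic ring with no step beyond the scatter. No evidence is available to explain this result.

Going by these compounds, whether a methyl group, a longer chain or a ring carrying an amine would fare alike on this nitrogen stays open. Also open, on these data alone, is whether oxan-4-yl would give the same result alongside the 4-bromophenyl group of compound 2.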